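Swap at the amine nitrogen in a two-compound series

The source may report more compounds than this note shows. Statements on the series, on what has been measured and on what is new or still open speak of the compounds shown alone.

Compound 2 `O=c1cc(-c2ccccc2)oc2cc(OCCCCNc3nc4ccc(I)cc4s3)cc(O)c12` gives 13.2 ug/mL in a functional assay on Ca-Ski cells (Homo sapiens) for cytotoxicity, read by sulforhodamine B assay, with a stated time of 48 h; on this read-out higher numbers stand for weaker inhibition and lower numbers for stronger inhibition. Going by the values given here, it holds the highest of the two numbers so far, yet sits within the scatter of compound 1 `O=c1cc(-c2ccccc2)oc2cc(OCCCCNc3nc4ccc(Cl)cc4s3)cc(O)c12`, which gives 12.4 ug/mL. Among the compounds with values here, the only measured step, a 1.1-fold higher number from compound 1 to compound 2 (0.03 log units; within the scatter), is accordingly read as no change.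

Compound 3 `O=c1cc(-c2ccccc2)oc2cc(OCCCCNc3nc4c(F)cc(F)cc4s3)cc(O)c12` carries 4,6-difluoro-1,3-benzothiazol-2-yl in place of 6-iodo-1,3-benzothiazol-2-yl on an amine nitrogen. Within the data shown here, no measured step alters the number or placing of halogens on this group, so the step from compound 1 to compound 2 is the sole guide; it lay within the scatter, and a further halogen change on the same group is therefore expected to leave the number close to that of compound 2, with no direction beyond the scatter. Compound 3 is estimated at 13 ug/mL in this assay, range 7 ug/mL to 25 ug/mL, which corresponds to an expected step of a 1.0-fold lower number from compound 2 to compound 3 (0.01 log units; within the scatter).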

Compound 3, half-maximal inhibitory concentration: 10.8 ug/mL
Compound 3: the middle estimate sits 1.2-fold (0.08 log units) above what was measured; the range from low to high includes it.
By their numbers in this assay, from the lowest: compounds 3, 1 and 2 (each within the scatter of the next).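

In this assay, a 1.2-fold lower number from compound 2 to compound 3 (0.09 log units; within the scatter) and a 1.1-fold lower number from compound 1 to compound 3 (0.06 log units; within the scatter) extend the earlier halogen comparison from one 6-halo group to another to a group with two fluorines, 4,6-difluoro-1,3-benzothiazol-2-yl. On the amine nitrogen, the 6-chloro, 6-iodo and 4,6-difluoro groups therefore all give values within the scatter of one another, so neither the identity nor the number of halogens across these three compounds separates them on this read-out. No independent measurement is available that bears on this result.

All three groups carry halogen, so the compounds shown leave open how the unsubstituted 1,3-benzothiazol-2-yl group would compare. Also open, from the compounds shown here alone, is whether a methoxy group or a carboxylic acid on this group, or a longer chain to the amine nitrogen, would give a step beyond the scatter.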